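The compounds below may be only part of what the source reports. "The series", "measured", "known", "first", "only" and "open" are said of these compounds alone.

Working notes on the series. Compound 1 `CCNC(=O)Nc1nc2cc(-c3cnc(N4CCC(C)(C(=O)O)CC4)nc3)cc(-c3ccccn3)c2s1` carries the 4-carboxy-4-methylpiperidin-1-yl group on the shared core. In an ADME assay on microsomes from liver (Mus musculus) for metabolic stability, read by LC-MS, tested at 10 uM (a lower number here means slower removal, a higher number faster removal of the compound), compound 1 reports only a limit of the assay, < 5.8 mL/min/kg, so no number stands for it. Compound 2 `CCNC(=O)Nc1nc2cc(-c3cnc(N4CCC(C)(C(=O)O)CC4)cn3)cc(-c3ccccn3)c2s1` likewise gives in this assay only a limit, < 5.8 mL/min/kg. On the numbers shown, compound 1 stands nowhere definite: both measured compounds sit at the limit of < 5.8 mL/min/kg in this assay, at which 2 of the 2 values shown sit, and no step between them can be sized. Compound 3 `CCNC(=O)Nc1nc2cc(-c3cnc(N4CCCC(C)(C(=O)O)CC4)nc3)cc(-c3ccccn3)c2s1` differs from compound 1 in one place: 4-carboxy-4-methylazepan-1-yl in place of 4-carboxy-4-methylpiperidin-1-yl on an aromatic carbon, in words 4-carboxy-4-methylazepan-1-yl in place of 4-carboxy-4-methylpiperidin-1-yl on an aromatic carbon. Among the measured compounds shown here, no measured step is available to weigh this change, so in this assay no shift beyond the scatter is expected from compound 1 to compound 3. The expected step is a step that the limit leaves unreadable from compound 1 to compound 3. Compound 3 is estimated at 5 mL/min/kg, within 2.5 mL/min/kg to 12 mL/min/kg, most likely again reported only as a limit.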

Compound 3, clearance: < 5.8 mL/min/kg
Compound 3: only a limit was reported; the forecaster's own chance of this, stated with the estimate: 65%; the middle value is on the limit's open side.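

Among the compounds shown here, no step from compound 1 to compound 3 can be read in this assay, since each gives only a limit: the limit of < 5.8 mL/min/kg in this assay, at which 3 of the 3 values shown sit. Whether 4-carboxy-4-methylazepan-1-yl in place of 4-carboxy-4-methylpiperidin-1-yl shifts clearance at all stays open with the compounds shown.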